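The source may hold more compounds than are shown below. What is called first, only, known or untested is meant among the compounds shown, and "the series" means these compounds.

Measured so far:
Compound 1 `Cc1ccc(N2CCN(S(=O)(=O)C[C@]34CC[C@H](CC3=O)C4(C)C)CC2)nc1` — > 31600 nM in a functional assay on CHO-K1 cells for antagonist activity at C-X-C chemokine receptor type 3 (Homo sapiens), read by FLIPR and calcium flux; a lower number here means a stronger inhibitor, a higher number a weaker inhibitor
Compound 2 `CC1(C)[C@@H]2CC[C@@]1(CS(=O)(=O)N1CCN(c3ccc(C(F)(F)F)cn3)C(c3ccccc3)C1)C(=O)C2` — > 31600 nM
Compound 3 `CN(CCN(C)S(=O)(=O)C[C@]12CC[C@H](CC1=O)C2(C)C)c1ccc(C(F)(F)F)cn1` — > 31600 nM

All three of these values are limits of the assay rather than numbers. Compound 1 sits at that limit, as do the other two, so that its position cannot be ranked against them: the picture is that (the limit of > 31600 nM in this assay, at which 3 of the 3 values shown sit). Among the compounds with values here, no step between measured compounds that differ in one place is available, so nothing measured says how a change at the ring nitrogen shifts the read-out.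

Compound 4 `CC1(C)[C@@H]2CC[C@@]1(CS(=O)(=O)N1CCN(c3ncc(Br)cn3)CC1)C(=O)C2` has not yet been measured. It differs from compound 1 as follows: 5-bromopyrimidin-2-yl in place of 5-methylpyridin-2-yl on an amine nitrogen in a ring. With every shown value resting at the limit, there is no basis for a sizeable step in either direction, and the step from compound 1 to compound 4 is expected to be a step that the limit leaves unreadable from compound 1 to compound 4. For compound 4 the estimated value in this assay is 40000 nM, with a range from 8000 nM to 200000 nM, and the most likely outcome is expected to be another limit rather than a number.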

Compound 4, half-maximal inhibitory concentration: 631 nM
For compound 4 the middle estimate is 63-fold (1.80 log units) above the measured one, and the stated range ends above it.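

In this assay, 5-bromopyrimidin-2-yl in place of 5-methylpyridin-2-yl on an amine nitrogen in a ring gives an at least 50-fold lower number from compound 1 to compound 4 (1.69 log units; beyond the scatter), a large step beyond the scatter. Compound 4, at 631 nM, therefore gives the first true number among the compounds shown, and it shows that a change at this one place, with the rest of the core of compound 1 kept, is enough to give a true number for the read-out. The earlier compounds could not show this, and every other value shown remains a limit of the assay: the limit of > 31600 nM in this assay, at which 3 of the 4 values shown sit.

From the compounds shown here alone, what stays open is which part of the change carries the step, the bromine or the added ring nitrogen, and a 5-bromopyridin-2-yl or a 5-methylpyrimidin-2-yl group at this place would separate the two. Also open, going by these compounds, is how the read-out would respond to a 5-chloropyrimidin-2-yl or a plain pyrimidin-2-yl group here, and whether the step would carry over to a different core.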